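The compounds below may be only part of what the source reports. "The series", "measured", "known", "first", "only" and "open" are said of these compounds alone.

Series notes. In an assay for inhibition of serine/threonine-protein kinase PLK2 (Homo sapiens), read by FRET and Z'-LYTE, with a stated time of 1 h (a lower number here means a stronger inhibitor, a higher number a weaker inhibitor), compound 1 `CCC1C(=O)N(C)c2cnc(Nc3ccc(S(=O)(=O)NC)cc3)nc2N1c1ccn(C)n1` gives 71.6 nM; compound 2 `CCC1C(=O)N(C)c2cnc(Nc3ccc(S(=O)(=O)NCCO)cc3)nc2N1c1ccn(C)n1` gives 478 nM; compound 3 `CCCCNC(=O)c1ccc2c(ccn2-c2ncc3c(n2)N(c2ccn(C)n2)C(CC)C(=O)N3C)c1` gives 159 nM. Compound 2 stands highest of the three in this assay, with compound 3 nearest and compound 1 furthest. Going by the values given here, the one measured step that bears on the sulfonamide nitrogen, a 6.7-fold higher number from compound 1 to compound 2 (0.82 log units; beyond the scatter), runs the opposite way from the change now considered. Compound 4 `CCC1C(=O)N(C)c2cnc(Nc3ccc(S(N)(=O)=O)cc3)nc2N1c1ccn(C)n1` carries hydrogen in place of 2-hydroxyethyl on a sulfonamide nitrogen. Among the compounds with values here, since the 2-hydroxyethyl group is removed entirely rather than exchanged for methyl, no measured pair matches the step exactly; the expectation rests on compound 1 with 71.6 nM and reads as a return toward that region. For compound 4 the expected step in this assay is a 5.3-fold lower number from compound 2 to compound 4 (0.73 log units; beyond the scatter), a lower number beyond the scatter. The estimate for compound 4 is 90 nM, range 35 nM to 250 nM.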

Compound 4, half-maximal inhibitory concentration: 121 nM
Estimate against measurement, compound 4: 1.3-fold (0.13 log units) below; the range from low to high includes it.
By their numbers in this assay, from the lowest: compounds 1, 4 and 3 (each within the scatter of the next, the first and the last beyond it); then compound 2.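

In this assay, taking the 2-hydroxyethyl group off the sulfonamide nitrogen gives a 4.0-fold lower number from compound 2 to compound 4 (0.60 log units; beyond the scatter) and so recovers most of the rise seen with that group, with no carbon left on this nitrogen. Hydrogen in place of methyl gives a 1.7-fold higher number from compound 1 to compound 4 (0.23 log units; within the scatter) and leaves the two groups indistinguishable here, so only 2-hydroxyethyl stands apart among the three. No measured evidence bears on this result. From the compounds shown here alone, whether the rise in compound 2 follows the chain or its hydroxyl stays open: an ethyl or a 2-methoxyethyl group on this nitrogen would separate the two.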